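The source may hold more compounds than are shown below. What is called first, only, known or untested is meant among the compounds shown, and "the series" means these compounds.

Compound 1 `CCc1ccc(NC(=O)c2cccc(/C=C3\CC(=O)N(c4ccccc4)C3=O)c2)cc1` is the starting point. In an ADME assay on NCM460 cells (Homo sapiens) for cytotoxicity, read by MTT assay, with a stated time of 72 h (a lower number here means a stronger inhibitor, a higher number a weaker inhibitor), compound 1 gives > 100000 nM, which is a limit of the assay and not a measured number. Two close relatives have been tested as well: compound 2 `Cc1ccc(NC(=O)c2cccc(/C=C3\CC(=O)N(c4ccccc4)C3=O)c2)cc1C` and compound 3 `Cc1cccc(NC(=O)c2cccc(/C=C3\CC(=O)N(c4ccccc4)C3=O)c2)c1`. In this assay compound 2 gives > 100000 nM, again only a limit. Compound 3 likewise gives only a limit in this assay, namely > 100000 nM. The measured steps a step that the two limits leave unreadable from compound 1 to compound 2, a step that the two limits leave unreadable from compound 1 to compound 3 and a step that the two limits leave unreadable from compound 2 to compound 3 therefore cannot be sized, because of the limit of > 100000 nM in this assay, at which 3 of the 3 values shown sit.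

Compound 4 `O=C(Nc1cccc(F)c1)c1cccc(/C=C2\CC(=O)N(c3ccccc3)C2=O)c1` is the next member of the series, and the change from compound 1 is 3-fluorophenyl in place of 4-ethylphenyl on an amide-type nitrogen. Within the data shown here, since every change at this position so far has left the value at the limit, the same outcome is expected here: compound 4 is estimated to give 150000 nM in this assay, within a range of 50000 nM to 500000 nM, most likely reported as a limit again. The expected step that the limit leaves unreadable from compound 1 to compound 4 is thus essentially none beyond the scatter.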

Compound 4, half-maximal inhibitory concentration: > 100000 nM
Compound 4: only a limit was reported; the forecaster's own chance of this, stated with the estimate: 85%; the middle value is on the limit's open side.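

No step between compound 4 and compound 1, compound 2 or compound 3 can be read, because each of these values is only a limit: the limit of > 100000 nM in this assay, at which 4 of the 4 values shown sit.

The compounds shown leave open how far apart these four truly lie in this assay, and whether any change on the amide-type nitrogen would give a measurable value.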